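This account rests on a few compounds, and the source may have more. Where it says the series, first, only, none or still open, it means among the compounds named here.

Measured compounds:
compound 1, `Cc1ccc(C(=O)Nc2cc(-c3ccccc3)nn2-c2ccccc2)cc1` — in an assay on CHO cells with metabotropic glutamate receptor 5 (Homo sapiens) as the target (a lower number here means that less compound is needed, a higher number that more compound is needed for the effect), compound 1 gives 30 nM
compound 2, `O=C(Nc1cc(-c2ccccc2)nn1-c1ccccc1)c1ccccc1Cl` — in this assay compound 2 gives 2500 nM
compound 3, `O=C(Nc1cc(-c2ccccc2)nn1-c1ccccc1)c1ccccc1` — in this assay compound 3 gives 40 nM

Compound 3 carries a plain benzoyl on the shared core. Its number sits close to that of compound 1, the two lying within the usual scatter of each other (a 1.3-fold higher number from compound 1 to compound 3 (0.12 log units; within the scatter)), while compound 2 stands far apart (a 63-fold lower number from compound 2 to compound 3 (1.80 log units; beyond the scatter)). Going by the values given here, the only large step among the measured compounds is thus the one from compound 1 to compound 2 (an 83-fold higher number from compound 1 to compound 2 (1.92 log units; beyond the scatter)), which exchanges the substituent pattern on the benzoyl ring.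

Compound 4, `O=C(Nc1cc(-c2ccccc2)nn1-c1ccccc1)c1cnccn1`, differs from compound 3 in one place: pyrazin-2-yl in place of phenyl on a carbonyl carbon. Among the compounds with values here, none of the measured steps exchanges the ring itself for an aza-aromatic; the measured steps only show that a methyl on this ring is tolerated and a chloro is not. Within the data shown here, the step from compound 3 to compound 4 therefore has no direct precedent, and the size of its effect in this assay is uncertain. A moderate rise in the number is expected, the estimated step being a 3.8-fold higher number from compound 3 to compound 4 (0.57 log units; beyond the scatter). For compound 4 the expected value in this assay is 150 nM, with a range from 40 nM to 600 nM.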

Compound 4, half-maximal effective concentration: 200 nM
Beside the measured number, compound 4's estimate is 1.3-fold (0.12 log units) below it; low and high end bracket the measured number.
By their numbers in this assay, from the lowest: compounds 1 and 3 (each within the scatter of the next); then compound 4; then compound 2.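

In this assay, going by these compounds alone, the earlier compounds varied only a substituent on the phenyl ring, whereas compound 4 shows that exchanging the ring itself for pyrazin-2-yl on this carbonyl carbon costs a modest step (a 5.0-fold higher number from compound 3 to compound 4 (0.70 log units; beyond the scatter)), with a step of similar class against the 4-methylphenyl group (a 6.7-fold higher number from compound 1 to compound 4 (0.82 log units; beyond the scatter)). The pyrazin-2-yl compound still stands well clear of the 2-chlorophenyl compound (a 13-fold lower number from compound 2 to compound 4 (1.10 log units; beyond the scatter)), so among these four compounds the ring exchange is a smaller step than the one to 2-chlorophenyl. Nothing available explains the rise brought by the pyrazin-2-yl ring.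

On these data alone, whether a single ring nitrogen, as in pyridin-2-yl, would give the same step remains open. So does the question of whether a methyl on the pyrazin-2-yl ring would be tolerated as it is on the phenyl ring.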